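Shortening the Acid Side Chain of Compound 2

A few compounds are considered here, and "the series" means these few. Any claim that something is new, unique, unknown or untested is made for them only; others in the source may bear on it.

Compound 2 `CC(C)(C)C(=O)CN1C(=O)N(CC(=O)Nc2cccc(CCC(=O)O)c2)N=C(C2CCCCC2)c2ccccc21` gives the lowest of the two numbers measured in a functional assay on stomach for antagonist activity at Gastrin/cholecystokinin type B receptor (Rattus norvegicus) (a higher number here means weaker binding, a lower number tighter binding), at 4.47 nM. Going by the values given here, its only neighbour, compound 1 `CN(c1cccc(NC(=O)CN2N=C(C3CCCCC3)c3ccccc3N(CC(=O)C(C)(C)C)C2=O)c1)c1nn[nH]n1`, gives 24 nM in this assay. Among the compounds with values here, the one measured step, a 5.4-fold lower number from compound 1 to compound 2 (0.73 log units; beyond the scatter), came from swapping the (2H-tetrazol-5-yl)(methyl)amino group for the 2-carboxyethyl chain. Compound 3 `CC(C)(C)C(=O)CN1C(=O)N(CC(=O)Nc2cccc(CC(=O)O)c2)N=C(C2CCCCC2)c2ccccc21` keeps the acid but cuts its chain shorter: carboxy in place of carboxymethyl on a saturated chain carbon bound to an aromatic carbon. Within the data shown here, no measured step shortens or lengthens this chain; the earlier step shows only that the acid-bearing chain gives a lower number than the tetrazole, not how much its length matters. Compound 3 is therefore expected to sit close to compound 2, with a step of a 1.6-fold higher number from compound 2 to compound 3 (0.19 log units; within the scatter) that may well stay within the scatter. The estimated value for compound 3 in this assay is 7 nM, within a range from 2.5 nM to 20 nM.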

Compound 3, dissociation constant: 9.77 nM
The estimate for compound 3 lay 1.4-fold (0.14 log units) below the measured number; low and high end bracket the measured number.
By their numbers in this assay, from the lowest: compound 2; then compound 3; then compound 1.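

The length of the acid chain counts at this position: in this assay, going from 2-carboxyethyl to carboxymethyl gives a 2.2-fold higher number from compound 2 to compound 3 (0.34 log units; beyond the scatter). The shorter acid chain still gives a lower number than the (2H-tetrazol-5-yl)(methyl)amino group, with a 2.5-fold lower number from compound 1 to compound 3 (0.39 log units; beyond the scatter), so among these three compounds both acid chains give lower numbers than that group. Nothing at hand explains why the longer of the two chains gives the lower number.

Going by these compounds alone, with only two chain lengths in view, it remains open whether a 3-carboxypropyl chain would lower the number further or raise it again, and how a carboxylic acid bonded directly to the aromatic carbon would compare. On these data alone, it is also open whether the end of the chain must be an acid at all, since an amine or a primary amide there could show how much the number depends on that group.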